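Swapping hydroxy for amino on a carbonyl carbon

The source may hold more compounds than are shown below. What is called first, only, known or untested is meant among the compounds shown, and "the series" means these compounds.

Of the compounds shown here, three sharing one core have been measured in an assay on brain (strain Sprague-Dawley) for inhibition of Amine oxidase [flavin-containing] B (Rattus norvegicus), read by spectrophotometry; a higher number here means a weaker inhibitor, a lower number a stronger inhibitor. Compound 1 `CCNC(=O)Nc1cc(=O)oc2cc(OCc3cccc(Cl)c3)ccc12` gives 31600 nM. Compound 2 `O=c1cc(CCBr)c2ccc(OCc3cccc(Cl)c3)cc2o1` gives 32.4 nM, and compound 3 `O=C(O)CCc1cc(=O)oc2cc(OCc3cccc(Cl)c3)ccc12` gives 1200 nM. Compound 3 thus stands second highest of the three numbers: the step of a 26-fold lower number from compound 1 to compound 3 (1.42 log units; beyond the scatter) is large, and so is a 37-fold higher number from compound 2 to compound 3 (1.57 log units; beyond the scatter). The step of a 980-fold lower number from compound 1 to compound 2 (2.99 log units; beyond the scatter) separates the other two compounds from each other.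

Compound 4 `NC(=O)CCc1cc(=O)oc2cc(OCc3cccc(Cl)c3)ccc12` differs from compound 3 only in the change (amino in place of hydroxy on a carbonyl carbon). Among the measured compounds shown here, no measured step alters this particular group. For the measured compounds named here, the only step that touches the end of the saturated chain is a 37-fold higher number from compound 2 to compound 3 (1.57 log units; beyond the scatter), which exchanged bromo for carboxy, a different kind of change. Nothing measured here bears directly on hydroxy giving way to amino. The expectation for compound 4 is therefore a number near that of compound 3, with a step of a 1.2-fold lower number from compound 3 to compound 4 (0.08 log units; within the scatter) expected to lie within the scatter or only slightly beyond it. Compound 4 is expected to show 1000 nM, with a plausible range from 250 nM to 4000 nM.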

Compound 4, half-maximal inhibitory concentration: 15.1 nM
Compound 4: middle estimate off by 66-fold (1.82 log units), on the high side; the measured number lies below the stated range.
By their numbers in this assay, from the lowest: compound 4; then compound 2; then compound 3; then compound 1.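

In this assay, the end of the saturated chain proves very sensitive to a one-atom change: amino in place of hydroxy on the carbonyl carbon gives a large step (a 79-fold lower number from compound 3 to compound 4 (1.90 log units; beyond the scatter)), although one heavy atom simply replaces another. Carbamoyl also gives a modest step from bromo (a 2.1-fold lower number from compound 2 to compound 4 (0.33 log units; beyond the scatter)), so compound 4 now has the lowest number of the set, and the 2-carbamoylethyl group stands far from the (ethylcarbamoyl)amino group (a 2100-fold lower number from compound 1 to compound 4 (3.32 log units; beyond the scatter)). Nothing available explains why this swap has so large an effect.

The compounds shown leave open whether both hydrogens on the amide nitrogen are needed, which an N-methyl or N,N-dimethyl amide at the chain end would test. They also leave open how a shorter or longer chain carrying the same carbamoyl group would compare.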